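The compounds below may be only part of what the source reports. "The series", "measured", "known", "first", "only" and "open" are said of these compounds alone.

The study starts from compound 1, `C=CCn1c(SCC(=O)Nc2ccc(C(C)=O)cc2)nnc1-c1ccccc1`, which in a functional assay on the whole organism (strain albino) for inhibition, with Rattus norvegicus as the target, read by paw edema, with stated times of 30 min and 3 h, at a dose of 0.28 mmol/kg by the oral route (a lower number here means less inhibition, a higher number more inhibition at the dose given (going by the name of the read-out)), gives 54%. This is the lowest of the three numbers measured. Among the measured compounds shown here, compound 2, `C=CCn1c(SCC(=O)Nc2ccc(/C(C)=N/O)cc2)nnc1-c1ccccc1`, gives 73%, and the change a number 19 percentage points higher from compound 1 to compound 2 (beyond the scatter) is the only single-point step measured, but it alters the group on the aniline, not the ring on the shared core. Compound 3, `CCn1c(SCC(=O)Nc2ccc(/C(C)=N/O)cc2)nnc1-c1ccc(OC)cc1`, gives 60%; it differs from compound 2 in two places at once, so its number cannot be tied to either change alone.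

Compound 4, `C=CCn1c(SCC(=O)Nc2ccc(C(C)=O)cc2)nnc1-c1ccc(OC)c(OC)c1`, is obtained from compound 1 by 3,4-dimethoxyphenyl in place of phenyl on an aromatic carbon. For the measured compounds named here, no measured step touches this position, so nothing measured bears directly on it. Going by the values given here, the only hint comes from compound 3, whose methoxy-bearing ring goes together with a number not far from that of compound 1. The expectation is therefore a step of a number 2 percentage points higher from compound 1 to compound 4 (within the scatter) that stays within the scatter. Compound 4 is estimated at 56%, in the range from 40% to 72%.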

Compound 4, a percentage reported as inhibition, in the whole organism at one dose (the size of the read-out at that dose, not a potency): 58%
Estimate against measurement, compound 4: 2 percentage points below; low and high end bracket the measured number.
By their numbers in this assay, from the lowest: compounds 1, 4 and 3 (each within the scatter of the next); then compound 2.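

Among the compounds shown here, this pair gives the first direct reading of the aromatic ring on the shared core. In this assay the change to 3,4-dimethoxyphenyl gives a number 4 percentage points higher from compound 1 to compound 4 (within the scatter) and so brings in a larger group, with 10 heavy atoms against 6 and 2 hydrogen-bond acceptors against 0, with no difference that can be told from the scatter. Nothing measured offers an explanation for this result.

As far as these compounds go, whether a carboxylic acid or an amine on this phenyl ring would give a number beyond the scatter remains open. From the compounds shown here alone, it is also open whether 3,4-dimethoxyphenyl would read the same alongside the oxime of compound 2, which gives 73% with a plain phenyl ring.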